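Isobutyl to isopropyl on the thiourea-bearing chain carbon

A few compounds are considered here, and "the series" means these few. Any claim that something is new, unique, unknown or untested is made for them only; others in the source may bear on it.

Measured so far, in a functional assay on A549 cells (Homo sapiens) for cytotoxicity, read by MTT assay; on this read-out higher numbers stand for weaker inhibition and lower numbers for stronger inhibition:
compound 1 `CC(C)C[C@@H](NC(=S)Nc1ccccc1)c1nc2ccccc2[nH]1`, 18700 nM
compound 2 `CC(C)C[C@H](NC(=S)Nc1ccccc1)c1nc2ccccc2[nH]1`, 28600 nM

Compound 1 stands, on the two numbers shown, side by side with compound 2: the step of a 1.5-fold higher number from compound 1 to compound 2 (0.18 log units; within the scatter) rests on the fact that compounds 1 and 2 differ only in the configuration as drawn and does not separate the pair beyond the scatter.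

Compound 3 `CC(C)[C@@H](NC(=S)Nc1ccccc1)c1nc2ccccc2[nH]1` is not yet measured. It differs from compound 1 by isopropyl in place of isobutyl on a saturated chain carbon bound to an amide-type nitrogen and an aromatic carbon. Within the data shown here, no measured step touches this change; the only step known, a 1.5-fold higher number from compound 1 to compound 2 (0.18 log units; within the scatter), concerns the configuration at that carbon and was within the scatter. A shorter branch of the same kind at this position gives no ground to expect a step beyond the scatter in either direction. Compound 3 is therefore expected to give 20000 nM, within 7000 nM to 55000 nM, an estimated step of a 1.1-fold higher number from compound 1 to compound 3 (0.03 log units; within the scatter).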

Compound 3, half-maximal inhibitory concentration: 31500 nM
Compound 3: middle estimate off by 1.6-fold (0.20 log units), on the low side, within the range that was stated.
By their numbers in this assay, from the lowest: compounds 1, 2 and 3 (each within the scatter of the next).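

In this assay, isopropyl in place of isobutyl on a saturated chain carbon bound to an amide-type nitrogen and an aromatic carbon gives a 1.7-fold higher number from compound 1 to compound 3 (0.23 log units; within the scatter) and does not separate the two compounds beyond the scatter. This is a second change at the same carbon that stays within the scatter, after the change of configuration, a 1.5-fold higher number from compound 1 to compound 2 (0.18 log units; within the scatter), so on the compounds shown neither change moves the number beyond it. Nothing available bears on a cause for the isopropyl step.

Going by these compounds, whether another kind of group on this carbon, such as an amine, a carboxylic acid or a longer chain, would give a step beyond the scatter stays open. Also open, on these data alone, is whether the opposite configuration would give a comparable number with isopropyl in place of isobutyl.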